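Trimming the amide on a shared core: aziridine to methylamide

This account rests on a few compounds, and the source may have more. Where it says the series, first, only, none or still open, it means among the compounds named here.

Compound 2 `Cc1cc(/C=C/C#N)cc(C)c1Oc1cc(Nc2ccc(C#N)cc2)c(N)cc1C(=O)N1CC1` carries a three-membered amine ring on its carbonyl. Going by the values given here, in a physicochemical assay for lipophilicity, read by HPLC, measured as octanol-water partition, with a stated time of 24 h, at pH 7.4 (on this read-out lower numbers stand for lower lipophilicity and higher numbers for higher lipophilicity), compound 2 gives 2.21, the lower of the two numbers measured; the only neighbour is compound 1 `Cc1cc(/C=C/C#N)cc(C)c1Oc1cc(Nc2ccc(C#N)cc2)c(N)cc1C(=O)NCCC(F)F`, which in this assay gives 3.58, so there was a number 1.37 log units lower from compound 1 to compound 2 (beyond the scatter). Compound 3 `CNC(=O)c1cc(N)c(Nc2ccc(C#N)cc2)cc1Oc1c(C)cc(/C=C/C#N)cc1C` differs from compound 2 in one place: methylamino in place of aziridin-1-yl on a carbonyl carbon. Among the compounds with values here, no measured step swaps these two groups, so only a loose guide exists: the single measured step shows that exchanging the group on this carbonyl can move this assay by a large amount, and the group entering here is smaller and brings a hydrogen-bond donor. A modest decrease is therefore expected, giving a number 0.41 log units lower from compound 2 to compound 3 (beyond the scatter) as the anticipated step. For compound 3 the estimated value in this assay is 1.8, with a range from 1.3 to 2.4.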

Compound 3, partition coefficient: 2.65
Compound 3: the middle estimate sits 0.85 log units below what was measured; the whole stated range lies below it.
By their numbers in this assay, from the lowest: compound 2; then compound 3; then compound 1.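

Exchanging aziridin-1-yl for methylamino on this carbonyl carbon gives a number 0.44 log units higher from compound 2 to compound 3 (beyond the scatter) in this assay, so here the entering group, with fewer heavy atoms and a hydrogen-bond donor, does not bring a lower number. Removing the 2,2-difluoroethyl part of the chain gives a number 0.93 log units lower from compound 1 to compound 3 (beyond the scatter), which places compound 3 in the middle of the three and leaves compound 2, not the compound with the smallest group, with the lowest number.

On these data alone, whether dimethylamino or azetidin-1-yl on this carbonyl would land nearer compound 2 or compound 3 remains open. A plain propylamino group would help separate the part played by the fluorine atoms of compound 1 from that of its chain length. No measurement here offers a cause for any of these steps.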